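This account rests on a few compounds, and the source may have more. Where it says the series, first, only, none or still open, it means among the compounds named here.

Measured so far in a functional assay on corpus cavernosum (Rattus norvegicus) for activation; on this read-out lower numbers stand for an effect already at smaller amounts and higher numbers for an effect only at larger amounts of compound:

- compound 1 `CCCCOc1ccccc1-c1nc2c(cnn2-c2ccccc2)c(=O)[nH]1`: 630 nM
- compound 2 `CCCCOc1ccccc1-c1nc2c(cnn2-c2ccc(Br)cc2)c(=O)[nH]1`: 4.89 nM
- compound 3 `Nc1ccccc1NCc1nc2c(cnn2-c2ccccc2)c(=O)[nH]1`: 6800 nM

Compound 1 and compound 2 share one core and differ in a single place: bromo in place of hydrogen on an aromatic carbon. In this assay this change gives a 130-fold lower number from compound 1 to compound 2 (2.11 log units; beyond the scatter). Compound 3 carries a different core; the difference between the two cores is not broken down here. In this assay compound 3 stands highest of the three, with compound 1 the nearest and compound 2 the furthest from it.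

Compound 4 `Nc1ccccc1NCc1nc2c(cnn2-c2ccc(Br)cc2)c(=O)[nH]1` is not yet measured. It stands to compound 3 as compound 2 stands to compound 1: bromo in place of hydrogen on an aromatic carbon. The place lines of the two changes read the same word for word, so this is the same kind of change, made on a different core. Among the compounds shown, this change has been seen only once, and the step it made was a 130-fold lower number from compound 1 to compound 2 (2.11 log units; beyond the scatter). A single example on another core cannot be taken over in full. In this assay the step expected for compound 4 is therefore smaller than the one measured, although still in the same direction, and is estimated as a 27-fold lower number from compound 3 to compound 4 (1.43 log units; beyond the scatter). Within the data shown here, that expectation rests on compound 3 giving 6800 nM and on the one measured step. Compound 4 is therefore estimated at 250 nM, with a range from 40 nM to 1500 nM.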

Compound 4, half-maximal effective concentration: 707 nM
Compound 4: middle estimate off by 2.8-fold (0.45 log units), on the low side, within the range that was stated.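

In this assay, the phenyl to 4-bromophenyl change on the core of compound 3 gives a 9.6-fold lower number from compound 3 to compound 4 (0.98 log units; beyond the scatter), so the direction seen on the core of compound 1 is seen again on a second core. The size of the step is not kept, and the two steps stand clearly apart: the same change on two cores in this assay, a 130-fold lower number (2.11 log units; beyond the scatter) from compound 1 to compound 2 and a 9.6-fold lower number (0.98 log units; beyond the scatter) from compound 3 to compound 4, 13-fold (1.13 log units) apart, beyond the scatter of two such steps This shows that, in these two pairs, the bromo group lowers the number on both cores but by a different amount on each; it does not show why the amounts differ, and two pairs are too few to give a rule for how much of the step would survive on any further core.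

It remains open whether a chloro, a fluoro or a methyl group in the same place would give a step like that of bromo, since phenyl to 4-bromophenyl is the only change on this ring among the compounds shown. Also open, on these data alone, is how the change would behave on a third core, for instance one carrying a carboxylic acid or a longer chain in place of the groups that set these two cores apart.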